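The source may report more compounds than this note shows. Statements on the series, on what has been measured and on what is new or still open speak of the compounds shown alone.

Three compounds have been measured:
compound 1, `COc1ccccc1N1CCN(CCn2nc(-n3cnc4ccccc43)ccc2=O)CC1`, with 33 nM;
compound 2, `COc1ccccc1N1CCN(CCCCCn2nc(-n3cnc4ccccc43)ccc2=O)CC1`, with 3.1 nM;
compound 3, `COc1ccccc1N1CCN(CCn2nc(-n3ccc4ccccc43)ccc2=O)CC1`, with 22.7 nM.

All three were tested in an assay on cell membranes from brain for binding affinity to Adrenergic receptor alpha-1 (Rattus norvegicus), read by radioligand binding; a lower number here means a stronger inhibitor, a higher number a weaker inhibitor. Compound 1 and compound 3 share the same core and differ in a single group: 1H-indol-1-yl in place of 1H-benzimidazol-1-yl on an aromatic carbon. That exchange produced a 1.5-fold lower number from compound 1 to compound 3 (0.16 log units; within the scatter), so the two values lie in the same range and neither compound can be called the stronger binder. Compound 2 carries a different core from compound 1; the difference between the two cores is not broken down here. Compound 2 is the strongest binder of the three, since its values stand apart from both compound 1 and compound 3 by more than the usual scatter.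

Compound 4, `COc1ccccc1N1CCN(CCCCCn2nc(-n3ccc4ccccc43)ccc2=O)CC1`, has not yet been measured in this assay. Among the measured compounds shown here, it is derived from compound 2 by 1H-indol-1-yl in place of 1H-benzimidazol-1-yl on an aromatic carbon, which is the same change, at the same place on the core, as the one that turned compound 1 into compound 3. Since compound 2 already holds the lowest number of the set, the question is whether this change moves it further. The expected step is a 1.3-fold lower number from compound 2 to compound 4 (0.13 log units; within the scatter), which rests on the measured step of a 1.5-fold lower number from compound 1 to compound 3 (0.16 log units; within the scatter) having stayed within the scatter. On that basis compound 4 is estimated to give about 2.3 nM in this assay, with a likely range from 0.8 nM to 7 nM.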

Compound 4, inhibition constant: 6.8 nM
The estimate for compound 4 lay 3.0-fold (0.47 log units) below the measured number, within the range that was stated.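

On the core of compound 2, putting 1H-indol-1-yl in place of 1H-benzimidazol-1-yl gives a 2.2-fold higher number from compound 2 to compound 4 (0.34 log units; beyond the scatter) in this assay, so here the exchange costs a modest amount of binding strength, whereas on the core of compound 1 it made no difference that could be told from the scatter. The change therefore did not carry over unaltered from one core to the other, and a step measured on one core was not a safe guide to the step on the other: the same change on two cores in this assay, a 1.5-fold lower number (0.16 log units; within the scatter) from compound 1 to compound 3 and a 2.2-fold higher number (0.34 log units; beyond the scatter) from compound 2 to compound 4, 3.2-fold (0.50 log units) apart, beyond the scatter of two such steps. This shows only that the size of this one step depended on the core in these two pairs; it does not show why, and two pairs give no rule for predicting the step on any further core.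

The compounds shown leave open how the two groups would compare on a core with a shorter or longer chain than those of compound 1 and compound 2, which would show whether the gap between the steps grows steadily with chain length or belongs to these two cores alone. They also leave open what a different group at this place, such as 1H-benzotriazol-1-yl or a simple amine, would do on each core.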